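Swapping the aryl group in a weak quinolinone antagonist

The compounds below may be only part of what the source reports. "The series", "measured", "known", "first", "only" and "open" are said of these compounds alone.

Three compounds measured in a functional assay on cells (Pituitary gland cell) for antagonist activity at Gonadotropin-releasing hormone receptor (Rattus norvegicus) (on this read-out higher numbers stand for weaker inhibition and lower numbers for stronger inhibition), share a core carrying a 2-(piperidin-2-yl)ethoxy group and a hydroxy group. Compound 1 `O=C(Nc1cc2c(OCCC3CCCCN3)c(-c3ccc(Cl)c(Cl)c3)c(O)nc2cc1Cl)NC1CC1` gives 18 nM in this assay. Compound 3 `Cc1cc(C)cc(-c2c(O)nc3cc(Cl)c(NC(=O)c4cnccn4)cc3c2OCCC2CCCCN2)c1` gives 1.8 nM. Compound 2 `Cc1ccc(-c2c(O)nc3cc(Cl)c([N+](=O)[O-])cc3c2OCCC2CCCCN2)c(C)c1`, which carries a nitro group and a 2,4-dimethylphenyl group, gives 400 nM; this is the highest number of the three, meaning the weakest inhibition, and it stands beyond the scatter from both compound 1 and compound 3. None of these three differ from each other in only one place, so no single measured step can be read off.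

Compound 4 `O=[N+]([O-])c1cc2c(OCCC3CCCCN3)c(-c3ccc4ccccc4c3)c(O)nc2cc1Cl` keeps everything in compound 2 except one group: naphthalen-2-yl in place of 2,4-dimethylphenyl on an aromatic carbon. For the measured compounds named here, no measured pair shows what this kind of exchange does in this assay, so the expectation rests on general judgement alone. A change of roughly the size of the scatter, in either direction, is expected, rather than a large gain or loss.

For compound 4 the estimated value in this assay is 500 nM, with a range from 100 nM to 2500 nM, which is expected to mean a step of a 1.3-fold higher number from compound 2 to compound 4 (0.10 log units; within the scatter).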

Compound 4, half-maximal inhibitory concentration: 53 nM
For compound 4 the middle estimate is 9.4-fold (0.97 log units) above the measured one, outside the stated range (below it).
By their numbers in this assay, from the lowest: compound 3; then compound 1; then compound 4; then compound 2.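

In this assay, placing naphthalen-2-yl instead of 2,4-dimethylphenyl on this aromatic carbon gives a 7.5-fold lower number from compound 2 to compound 4 (0.88 log units; beyond the scatter), a step beyond the scatter. For the compounds shown here, this is the first clean evidence that the aryl group at this position, ortho to both the 2-(piperidin-2-yl)ethoxy group and the hydroxy group, affects the read-out: the nitro group and the rest of the molecule stay fixed, whereas compound 1, compound 2 and compound 3 all differ from each other in more than one place. Nothing presented here explains why the number falls.

Going by these compounds alone, the single step cannot separate the effect of adding a second aromatic ring from that of losing the two methyl groups, and a methoxy group or a carboxylic acid on the aryl group would test a different kind of substituent at this position. As far as these compounds go, it also remains open whether naphthalen-2-yl would give a similar step when the nitro group is replaced by the groups found at that place in compound 1 or compound 3.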